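Removing the nitro group from compound 3

A few compounds are considered here, and "the series" means these few. Any claim that something is new, unique, unknown or untested is made for them only; others in the source may bear on it.

Measured in a functional assay on A549 cells (Homo sapiens) for cytotoxicity, read by MTT assay, with a stated time of 72 h; on this read-out higher numbers stand for weaker inhibition and lower numbers for stronger inhibition:
- Compound 1 `CNC(=O)c1cc(Oc2ccc(C3=NNC(c4ccc(C#N)cc4)C3)cc2)ccn1` gives 17400 nM
- Compound 2 `CNC(=O)c1cc(Oc2ccc(C3=NNC(c4ccc(F)cc4Cl)C3)cc2)ccn1` gives 13700 nM
- Compound 3 `CNC(=O)c1cc(Oc2ccc(C3=NNC(c4ccc([N+](=O)[O-])cc4)C3)cc2)ccn1` gives 19500 nM

These three compounds share one core and differ only in the substituted phenyl group on a saturated ring carbon. Among the compounds with values here, on these numbers, compound 3 stands level with the other two, since no step among them leaves the scatter of repeated measurements.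

Compound 4 `CNC(=O)c1cc(Oc2ccc(C3=NNC(c4ccccc4)C3)cc2)ccn1` is the next to be tested. It carries hydrogen in place of nitro on an aromatic carbon, so 4-nitrophenyl becomes phenyl (hydrogen in place of nitro on an aromatic carbon). Within the data shown here, no measured pair shows this exact change, and no measured compound carries a plain phenyl group, so the evidence is indirect. The nearest step is nitro in place of cyano, which gave a 1.1-fold higher number from compound 1 to compound 3 (0.05 log units; within the scatter) and stayed small. The two changes of the whole phenyl group gave a 1.3-fold lower number from compound 1 to compound 2 (0.10 log units; within the scatter) and a 1.4-fold higher number from compound 2 to compound 3 (0.15 log units; within the scatter) and were also small. Every change tried so far has left the number within the scatter, so no step beyond the scatter is expected, and no direction can be favoured. The expected result is a 1.1-fold lower number from compound 3 to compound 4 (0.06 log units; within the scatter) in this assay as an estimate. Compound 4 is estimated at 17000 nM with an expected range from 9000 nM to 32000 nM for its measurement.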

Compound 4, half-maximal inhibitory concentration: 8600 nM
The estimate for compound 4 lay 2.0-fold (0.30 log units) above the measured number; the whole stated range lies above it.
By their numbers in this assay, from the lowest: compounds 4, 2, 1 and 3 (each within the scatter of the next, the first and the last beyond it).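

In this assay, within the data shown here, plain phenyl gives the first changes to leave the scatter: taking the nitro group off this aromatic carbon gives a 2.3-fold lower number from compound 3 to compound 4 (0.36 log units; beyond the scatter), and taking the cyano group off the same carbon gives a 2.0-fold lower number from compound 1 to compound 4 (0.31 log units; beyond the scatter), both modest steps. Swapping nitro for cyano had shown nothing, so these steps add something new: leaving this carbon bare separates compound 4 from compounds that carry either group, even though those two groups could not be told apart from each other. The pattern does not extend to every substituted ring, since replacing 2-chloro-4-fluorophenyl with phenyl gives a 1.6-fold lower number from compound 2 to compound 4 (0.20 log units; within the scatter), which stays within the scatter, and nothing measured here bears on the reason for any of these steps.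

As far as these compounds go, it remains open whether a methyl, a methoxy or an amino group on this carbon would stay level with compound 4 or move the number back towards compound 3. From the compounds shown here alone, it is also open whether a single chlorine or fluorine on the phenyl ring would behave like hydrogen, which would help show how much of the 2-chloro-4-fluorophenyl result comes from each halogen.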